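Swapping a chlorophenyl for an aminophenyl on a weak inhibitor

This account rests on a few compounds, and the source may have more. Where it says the series, first, only, none or still open, it means among the compounds named here.

Compound 1, `COc1cc(-c2nnc(C3CCc4cc(F)ccc4O3)o2)cc(OC)c1OC`, gives 43200 nM in a functional assay; a lower number here means a stronger inhibitor, a higher number a weaker inhibitor.
Compound 2, `Fc1ccc2c(c1)CCC(c1nnc(-c3cn(Cc4c(F)cccc4F)nn3)o1)O2`, gives 23100 nM in this assay.
Compound 3, `Fc1ccc2c(c1)CCC(c1nnc(-c3cccc(Cl)c3)o1)O2`, gives 23100 nM in this assay.

Compound 3 stands level with compound 2 at the digits shown, and compound 1 lies within the usual scatter of both, so the three numbers cannot be placed in any order. All three are weak inhibitors. Compound 4, `Nc1ccc(-c2nnc(C3CCc4cc(F)ccc4O3)o2)cc1`, differs from compound 3 in one place: 4-aminophenyl in place of 3-chlorophenyl on an aromatic carbon. For the measured compounds named here, no measured pair shows this change, so its effect is unknown. The expected step in this assay from compound 3 to compound 4 is a 1.3-fold higher number from compound 3 to compound 4 (0.11 log units; within the scatter), small and of uncertain direction, likely within the scatter. Compound 4 is therefore expected to give about 30000 nM, within a range from 8000 nM to 110000 nM.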

Compound 4, half-maximal inhibitory concentration: 34900 nM
For compound 4 the middle estimate is 1.2-fold (0.07 log units) below the measured one, within the range that was stated.
By their numbers in this assay, from the lowest: compounds 2, 3, 4 and 1 (each within the scatter of the next).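

In this assay, for the compounds shown here, putting 4-aminophenyl in place of 3-chlorophenyl gives a 1.5-fold higher number from compound 3 to compound 4 (0.18 log units; within the scatter) and provides the first comparison of compounds that differ in only one place. On this aromatic carbon, the swap adds a hydrogen-bond donor and acceptor and moves both the chlorine and the point of substitution, yet no clear difference in inhibition appears, and both compounds remain weak inhibitors. No measurement here offers a reason for this. Still open, on these data alone, is whether a carboxylic acid or a sulfonamide on this phenyl ring would give a stronger inhibitor.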